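Sulfonamide variation on a shared thione core: compound 4

A few compounds are considered here, and "the series" means these few. Any claim that something is new, unique, unknown or untested is made for them only; others in the source may bear on it.

Measured compounds:
Compound 1, `Cc1cc(C)c(S(=O)(=O)NC2=NCCN2C(=S)SN2CCn3c2nsc3=S)c(C)c1`: in a functional assay on KYSE-510 cells (Homo sapiens) for antiproliferative activity, read by crystal violet staining, with a stated time of 96 h (a lower number here means a stronger inhibitor of growth, a higher number a weaker inhibitor of growth), compound 1 gives >= 20000 nM, which is a limit of the assay.
Compound 2, `COc1cccc(S(=O)(=O)NC2=NCCN2C(=S)SN2CCn3c2nsc3=S)c1`: in this assay compound 2 gives >= 20000 nM, again a limit of the assay.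
Compound 3, `O=[N+]([O-])c1ccc(S(=O)(=O)NC2=NCCN2C(=S)SN2CCn3c2nsc3=S)cc1`: in this assay compound 3 gives >= 20000 nM, also a limit of the assay.

Compound 2 stands nowhere definite on the numbers shown: its value is a limit, and the two other values shown are limits as well (the limit of >= 20000 nM in this assay, at which 3 of the 3 values shown sit). The steps among the measured compounds are accordingly unreadable: a step that the two limits leave unreadable from compound 1 to compound 2, a step that the two limits leave unreadable from compound 1 to compound 3 and a step that the two limits leave unreadable from compound 2 to compound 3. None of them tells whether any change at the sulfonyl sulfur moves growth inhibition at all.

Compound 4, `O=S(=O)(NC1=NCCN1C(=S)SN1CCn2c1nsc2=S)c1ccccc1Cl`, is not yet measured. It differs from compound 2 as follows: 2-chlorophenyl in place of 3-methoxyphenyl on a sulfonyl sulfur. All three measured steps at the same position bear on this change, but each is hidden by the limit, so no size or direction can be read from them. Nothing in the series points to growth inhibition within the measurable range.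

Compound 4 is therefore expected to sit at the limit again, with an estimate of 25000 nM in this assay, ranging from 12000 nM to 60000 nM. The step this estimate implies is a step that the limit leaves unreadable from compound 2 to compound 4, expected to be none beyond the scatter.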

Compound 4, concentration for 50% growth inhibition: >= 20000 nM
Compound 4 gave a limit, no number; the forecaster's own chance of this, stated with the estimate: 80%; the middle value is on the limit's open side.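

In this assay compound 4 gives >= 20000 nM, a limit of the assay, so the steps to it from compound 1, compound 2 and compound 3 cannot be read: the limit of >= 20000 nM in this assay, at which 4 of the 4 values shown sit.

The compounds shown leave open whether any group on the sulfonyl sulfur moves growth inhibition in this assay at all, or whether the shared core reaches the measurable range.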